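Lengthening the chain: from compound 2 to compound 3

The source may report more compounds than this note shows. Statements on the series, on what has been measured and on what is new or still open speak of the compounds shown alone.

- compound 1 `CCCCC(CCO)n1cnc2c(N)ncnc21`: > 50000 nM, a limit
- compound 2 `CCCCCCCCC(CCO)n1cnc2c(N)ncnc21`: 20700 nM
- compound 3 `CCCCCCCCCC(CCO)n1cnc2c(N)ncnc21`: not yet measured

For the measured compounds named here, in a functional assay on SW480 cells (Homo sapiens) for antiproliferative activity, read by MTT assay, with a stated time of 48 h (on this read-out lower numbers stand for stronger inhibition and higher numbers for weaker inhibition), compound 2 gives 20700 nM, the only exact number so far. Compound 1 is reported only as a limit, > 50000 nM.

Compound 3 departs from compound 2 by methyl in place of hydrogen on a saturated chain carbon, nine bonds along the chain from an aromatic nitrogen.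

Going by the values given here, one measured step bears on this: an at least 2.4-fold lower number from compound 1 to compound 2 (0.38 log units; beyond the scatter). That change was a butyl, so a methyl is expected to give a smaller shift in the same direction, probably within the scatter. The expected change is a 1.3-fold lower number from compound 2 to compound 3 (0.11 log units; within the scatter). Compound 3 is estimated at 16000 nM, with an expected range of 8000 nM to 32000 nM.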

Compound 3, half-maximal inhibitory concentration: 6030 nM
Compound 3: the middle estimate sits 2.7-fold (0.42 log units) above what was measured; measured number outside the range, below it.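

In this assay, methyl in place of hydrogen on a saturated chain carbon, nine bonds along the chain from an aromatic nitrogen, gives a 3.4-fold lower number from compound 2 to compound 3 (0.54 log units; beyond the scatter), so a methyl alone at this place moves the number beyond the scatter. Taken together, the chain extensions give an at least 8.2-fold lower number from compound 1 to compound 3 (0.91 log units; beyond the scatter). That span is open-ended, as the value for compound 1 is a limit: the limit of > 50000 nM in this assay, at which 1 of the 3 values shown sits.

As far as these compounds go, whether a longer chain lowers the number further remains open. So does the effect of an amine or a carboxylic acid in place of the hydroxyl.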